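A methyl group placed differently on a shared core

The source may hold more compounds than are shown below. What is called first, only, known or untested is meant among the compounds shown, and "the series" means these compounds.

Three compounds built on one shared core were tested in a functional assay on RPMI 8402 cells (Homo sapiens) for cytotoxicity; on this read-out higher numbers stand for weaker inhibition and lower numbers for stronger inhibition. Compound 1 `N#Cc1ccc2[nH]c(-c3ccc4[nH]c(-c5ccccc5)nc4c3)nc2c1` gives only a limit in this assay, > 25000 nM. Compound 2 `Cc1ccc(-c2nc3cc(-c4nc5cc(C#N)ccc5[nH]4)ccc3[nH]2)cc1` differs from compound 1 by methyl in place of hydrogen on an aromatic carbon, and in this assay compound 2 gives 570 nM, which is an at least 43-fold lower number from compound 1 to compound 2 (1.64 log units; beyond the scatter). Compound 3 `CN1CCN(c2ccc3[nH]c(-c4ccc5[nH]c(-c6ccccc6)nc5c4)nc3c2)CC1` differs from compound 1 by 4-methylpiperazin-1-yl in place of cyano on an aromatic carbon, and in this assay compound 3 gives 490 nM, which is an at least 51-fold lower number from compound 1 to compound 3 (1.70 log units; beyond the scatter). Both steps start from the limit of > 25000 nM in this assay, at which 1 of the 3 values shown sits, so their true size is not known, and the values of compound 2 and compound 3 sit close together.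

Compound 4 `Cc1ccccc1-c1nc2cc(-c3nc4cc(N5CCN(C)CC5)ccc4[nH]3)ccc2[nH]1` has not been measured. It differs from compound 3 by methyl in place of hydrogen on an aromatic carbon. This is the same kind of change as from compound 1 to compound 2, but not the same: there the methyl sat para to a large group, here it sits ortho to a large group. A step as large as an at least 43-fold lower number from compound 1 to compound 2 (1.64 log units; beyond the scatter) is not expected, since compound 3 already gives 490 nM rather than a limit. Compound 4 is expected to give about 350 nM, with a likely range from 70 nM to 1800 nM, meaning an expected step of a 1.4-fold lower number from compound 3 to compound 4 (0.15 log units; within the scatter).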

Compound 4, half-maximal inhibitory concentration: 590 nM
For compound 4 the middle estimate is 1.7-fold (0.23 log units) below the measured one, and the stated range covers the measured number.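

In this assay, adding the methyl to the core of compound 3 changes little, with a 1.2-fold higher number from compound 3 to compound 4 (0.08 log units; within the scatter), so a large gain seen on one core did not carry over to the other, and the two steps disagree: the same change on two cores in this assay, an at least 43-fold lower number (1.64 log units; beyond the scatter) from compound 1 to compound 2 and a 1.2-fold higher number (0.08 log units; within the scatter) from compound 3 to compound 4, at least 52-fold (1.72 log units) apart, beyond the scatter of two such steps. The size of the earlier step stays uncertain, since its starting point, compound 1, gives a limit and not a number: the limit of > 25000 nM in this assay, at which 1 of the 4 values shown sits. This does not show that the core alone decides the outcome, since the two steps differ in two ways at once: the cores carry nitrile or 4-methylpiperazin-1-yl, and in compound 4 the methyl sits ortho to a large group, whereas in compound 2 it does not.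

The compounds shown leave open whether the 2-methylphenyl group would give a large step on the core of compound 1, which would separate these two differences. They also leave open how an ethyl group, a chlorine or an amine in place of the methyl would read in this assay.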